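Pyrazole anilines against melanoma cells: chloro for methyl

The source may hold more compounds than are shown below. What is called first, only, known or untested is meant among the compounds shown, and "the series" means these compounds.

Measured compounds:
compound 1, `Fc1ccc(NCc2cn(-c3ccccc3)nc2-c2ccc(Cl)cc2)cc1`, 2120 nM
compound 2, `Cc1ccc(-c2nn(-c3ccccc3)cc2CNc2ccc(F)cc2)cc1`, 5670 nM
compound 3, `Cc1ccc(-c2nn(-c3ccccc3)cc2CNc2ccc(Br)cc2)cc1`, 6760 nM

Three compounds sharing one core were tested in a functional assay on B16-F10 cells (Mus musculus) for antiproliferative activity, read by MTT assay, with a stated time of 48 h; on this read-out lower numbers stand for stronger inhibition and higher numbers for weaker inhibition. Compound 1 `Fc1ccc(NCc2cn(-c3ccccc3)nc2-c2ccc(Cl)cc2)cc1` gives 2120 nM, compound 2 `Cc1ccc(-c2nn(-c3ccccc3)cc2CNc2ccc(F)cc2)cc1` gives 5670 nM, and compound 3 `Cc1ccc(-c2nn(-c3ccccc3)cc2CNc2ccc(Br)cc2)cc1` gives 6760 nM. Compounds 2 and 3 differ by bromo in place of fluoro on an aromatic carbon, and the step is a 1.2-fold higher number from compound 2 to compound 3 (0.08 log units; within the scatter). Compounds 2 and 1 differ by chloro in place of methyl on an aromatic carbon, which gave a 2.7-fold lower number from compound 2 to compound 1 (0.43 log units; beyond the scatter).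

Compound 4 `Clc1ccc(-c2nn(-c3ccccc3)cc2CNc2ccc(Br)cc2)cc1` is not yet measured; it differs from compound 3 by chloro in place of methyl on an aromatic carbon, the same change, at the same place, as that from compound 2 to compound 1. For compound 4 a step of a 2.7-fold lower number from compound 3 to compound 4 (0.43 log units; beyond the scatter) in this assay is expected, resting on the step from compound 2 to compound 1, a 2.7-fold lower number from compound 2 to compound 1 (0.43 log units; beyond the scatter), applied to compound 3. Compound 4 is therefore estimated at 2500 nM, in a range from 1200 nM to 5200 nM.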

Compound 4, half-maximal inhibitory concentration: 3010 nM
The estimate for compound 4 lay 1.2-fold (0.08 log units) below the measured number; low and high end bracket the measured number.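

In this assay, the change from 4-methylphenyl to 4-chlorophenyl gave a 2.2-fold lower number from compound 3 to compound 4 (0.35 log units; beyond the scatter), and it carried over between the fluoro and bromo cores: the same change on two cores in this assay, a 2.7-fold lower number (0.43 log units; beyond the scatter) from compound 2 to compound 1 and a 2.2-fold lower number (0.35 log units; beyond the scatter) from compound 3 to compound 4, 1.2-fold (0.08 log units) apart, within the scatter of two such steps Bromo in place of fluoro gave a 1.4-fold higher number from compound 1 to compound 4 (0.15 log units; within the scatter), which again stayed within the scatter on both cores: the same change on two cores in this assay, a 1.2-fold higher number (0.08 log units; within the scatter) from compound 2 to compound 3 and a 1.4-fold higher number (0.15 log units; within the scatter) from compound 1 to compound 4, 1.2-fold (0.08 log units) apart, within the scatter of two such steps This shows each change behaving alike across this one pair of cores, but it does not show that either step would hold on cores altered anywhere else.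

The compounds shown leave open what a methoxy group, a nitrile or a carboxylic acid would do in place of chloro or methyl. They also leave open whether these steps would hold in other cell lines.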